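Benzofuranyl analogue of a nucleoside pair at the assay ceiling

The compounds below may be only part of what the source reports. "The series", "measured", "known", "first", "only" and "open" are said of these compounds alone.

Compound 2 `O=c1[nH]cnc2c1c(-c1ccsc1)cn2[C@@H]1O[C@H](CO)[C@@H](O)[C@H]1O` is a nucleoside whose thiophen-3-yl group is the only point of difference from compound 1 `O=c1[nH]cnc2c1c(-c1cccs1)cn2[C@@H]1O[C@H](CO)[C@@H](O)[C@H]1O`. In a functional assay on HeLa S3 cells (Homo sapiens) for antiproliferative activity, read by XTT assay, with a stated time of 72 h (on this read-out lower numbers stand for stronger inhibition and higher numbers for weaker inhibition), compound 1 gives > 20000 nM, which is a limit of the assay and not a number. In this assay compound 2 likewise gives > 20000 nM, again a limit. The step that the two limits leave unreadable from compound 1 to compound 2 therefore cannot be read, since both values sit at the same limit (the limit of > 20000 nM in this assay, at which 2 of the 2 values shown sit). Compound 3 `O=c1[nH]cnc2c1c(-c1cc3ccccc3o1)cn2[C@@H]1O[C@H](CO)[C@@H](O)[C@H]1O` differs from compound 2 by 1-benzofuran-2-yl in place of thiophen-3-yl on an aromatic carbon. Within the data shown here, no measured step speaks to this change; the only step known is unreadable, so no direction beyond the scatter can be foreseen for it. Compound 3 is expected to remain near the same limit, an estimated 20000 nM with a range from 5000 nM to 50000 nM. The expected step of a number no higher from compound 2 to compound 3 (the limit leaves the size open) is thus estimated as essentially none.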

Compound 3, half-maximal inhibitory concentration: > 20000 nM
Compound 3: no number, only a limit; the forecaster's own chance of this, stated with the estimate: 70%; the middle value sits exactly at the limit.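

No step from compound 1, compound 2 or compound 3 to one another can be read in this assay, as each value is a limit and not a number: the limit of > 20000 nM in this assay, at which 3 of the 3 values shown sit.

The compounds shown leave open whether the thiophen-2-yl, thiophen-3-yl and 1-benzofuran-2-yl groups differ at all on this read-out.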